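Fluoro to trifluoromethyl on the aryl ether

This account rests on a few compounds, and the source may have more. Where it says the series, first, only, none or still open, it means among the compounds named here.

Measured so far in a functional assay on CHO cells for antagonist activity at prostaglandin E2 receptor EP4 subtype (Homo sapiens), read by calcium flux, with a stated time of 15 min; a lower number here means a stronger inhibitor, a higher number a weaker inhibitor:
compound 1 `C[C@H](NC(=O)c1nnn(Cc2ccc(F)cc2)c1C(F)(F)F)c1ccc(C(=O)O)cc1`, > 10000 nM, a limit of the assay
compound 2 `C[C@H](NC(=O)c1nnn(Cc2ccc(C(F)(F)F)cc2)c1C(F)(F)F)c1ccc(C(=O)O)cc1`, > 10000 nM, also a limit
compound 3 `C[C@H](NC(=O)c1c(-c2ccccc2)nnn1CCOc1ccc(F)cc1)c1ccc(C(=O)O)cc1`, 3.1 nM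

Compound 1 and compound 2 both sit at the limit of > 10000 nM in this assay, at which 2 of the 3 values shown sit, so the step that the two limits leave unreadable from compound 1 to compound 2 cannot be read. The change there is trifluoromethyl in place of fluoro on an aromatic carbon. How the core of compound 1 differs from the core of compound 3 is not broken down here. Compound 4 `C[C@H](NC(=O)c1c(-c2ccccc2)nnn1CCOc1ccc(C(F)(F)F)cc1)c1ccc(C(=O)O)cc1` carries the same change on the core of compound 3, (trifluoromethyl in place of fluoro on an aromatic carbon), at a place described in the same words as before. For the measured compounds named here, since the only measured instance of this change gives no size, the step of a 1.3-fold higher number from compound 3 to compound 4 (0.11 log units; within the scatter) is expected to stay within the usual scatter. Compound 4 is therefore estimated at 4 nM in this assay, from 1.5 nM to 12 nM.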

Compound 4, half-maximal inhibitory concentration: 49.1 nM
Compound 4: middle estimate off by 12-fold (1.09 log units), on the low side; the measured number lies above the stated range.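

Trifluoromethyl in place of fluoro on an aromatic carbon gives a 16-fold higher number from compound 3 to compound 4 (1.20 log units; beyond the scatter) in this assay and so is not neutral on this core. This is a single pair, so it gives the size of the change on one core only, and what is shown offers no cause for it. How the change carries from one core to another stays unknown, because both compounds of the other instance, compound 1 and compound 2, are limits of the assay and give no readable size: the limit of > 10000 nM in this assay, at which 2 of the 4 values shown sit.

Still open, as far as these compounds go, is what a nitrile, a chlorine or a methoxy group would give in the same place. Also open, from the compounds shown here alone, is whether a longer chain to the aryl ether would keep the value of compound 3 at 3.1 nM in this assay on this core.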